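Aryl swap on the shared core: expectation for compound 3

The compounds below may be only part of what the source reports. "The series", "measured", "known", "first", "only" and "open" are said of these compounds alone.

Among the measured compounds shown here, compound 1 `C=CCn1c(=O)/c(=C\c2cc(F)ccc2C)[nH]c(=O)/c1=C\c1ccccc1OC` is the single entry with a number in a functional assay on HeLa cells (Homo sapiens) for cytotoxicity, read by CCK-8 assay, with a stated time of 72 h; a higher number here means a weaker inhibitor, a lower number a stronger inhibitor; in this assay compound 1 gives 2900 nM. Compound 2 `COc1ccccc1/C=c1/[nH]c(=O)/c(=C\c2ccccc2OC)n(C)c1=O` is the other entry, and in this assay compound 2 is reported as "not active" (no number reported), with no number attached. Compound 3 `C=CCn1c(=O)/c(=C\c2ccc(Cl)c(Cl)c2)[nH]c(=O)/c1=C\c1ccccc1OC` differs from compound 1 in one place (3,4-dichlorophenyl in place of 5-fluoro-2-methylphenyl on a double-bonded chain carbon bound to an aromatic carbon). For the measured compounds named here, no step between measured compounds is available for this change, so the expected step from compound 1 to compound 3 in this assay is a 1.0-fold higher number from compound 1 to compound 3 (0.01 log units; within the scatter), within the scatter, in no firm direction. Compound 3 is therefore estimated at 3000 nM, with a range of 800 nM to 12000 nM.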

Compound 3, half-maximal inhibitory concentration: "not active" (no number reported)
For compound 3 the study gives words and no number; there is nothing to compare the estimate with.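

Among the compounds shown here, compound 3 carries words and no number in this assay, so no step from compound 1 to compound 3 can be read. The compounds shown leave open how large any effect of exchanging 5-fluoro-2-methylphenyl for 3,4-dichlorophenyl is. No available evidence bears on this result.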